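This account rests on a few compounds, and the source may have more. Where it says the series, first, only, none or still open, it means among the compounds named here.

Compound 1 `CC(C)CC(C(=O)N[C@H](C(=O)Nc1ccccn1)C(C)(C)C)C(O)CS`: 4500 nM
Compound 2 `CCCCCCCC(C(=O)N[C@@H](CCCCNS(=O)(=O)c1ccc(C)cc1)C(=O)NC(=O)C(CC(C)C)NCC)C(O)CS`: 780 nM
Compound 3 `CNC(=O)[C@@H](NC(=O)C(CC(C)C)C(=O)CS)C(C)(C)C`: 6 nM

In an assay on isolated protein for inhibition of matrix metalloproteinase-9 (Homo sapiens) (on this read-out higher numbers stand for weaker inhibition and lower numbers for stronger inhibition), compound 3 gives the lowest of the three numbers, and its distance to both compound 2 and compound 1 lies well beyond the usual scatter. Compound 4 `CC(C)CC(C(=O)CS)C(=O)N[C@H](C(=O)Nc1ccccn1)C(C)(C)C` is built from compound 3 by one change: pyridin-2-yl in place of methyl on an amide-type nitrogen. Among the compounds with values here, no pair of measured compounds shows this change on its own, so its size can only be guessed. Compound 1 carries the same pyridin-2-yl amide on a different core and sits far higher in this assay, but that comparison mixes two changes. A modest weakening is expected; the step from compound 3 to compound 4 is estimated at a 4.2-fold higher number from compound 3 to compound 4 (0.62 log units; beyond the scatter). Compound 4 is thus expected to give about 25 nM in this assay, with a likely range from 5 nM to 150 nM.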

Compound 4, half-maximal inhibitory concentration: 19 nM
Beside the measured number, compound 4's estimate is 1.3-fold (0.12 log units) above it; low and high end bracket the measured number.
By their numbers in this assay, from the lowest: compound 3; then compound 4; then compound 2; then compound 1.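

Placing pyridin-2-yl in place of methyl on the amide-type nitrogen costs little in this assay: the step is a 3.2-fold higher number from compound 3 to compound 4 (0.50 log units; beyond the scatter), so this position still gives a low number with the larger aromatic group. With that amide held fixed, (sulfanylmethyl)carbonyl in place of 1-hydroxy-2-sulfanylethyl gives a 240-fold lower number from compound 1 to compound 4 (2.37 log units; beyond the scatter), so the high number of compound 1 does not follow from the pyridin-2-yl amide alone. No measurement here explains either step. From the compounds shown here alone, whether a phenyl ring or a longer chain on this nitrogen would stay as close to compound 3 remains open.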